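The source may hold more compounds than are shown below. What is called first, only, known or untested is meant among the compounds shown, and "the series" means these compounds.

Working notes on the series.

Compound 1 `COc1cc2c(Oc3ccc(NC(=O)c4cc(-c5ccc(Cl)c(Cl)c5)nc5ccccc45)cc3F)ccnc2cc1OCCCN1CCCCC1` and compound 2 `COc1cc2c(Oc3ccc(NC(=O)c4cc(-c5ccc(Cl)c(Cl)c5)nc5ccccc45)cc3F)ccnc2cc1OCCCN1CCCC1` share one core and differ only in the amine at the end of the chain. In a functional assay on HT-29 cells (Homo sapiens) for cytotoxicity, read by MTT assay, with a stated time of 72 h (a lower number here means a stronger inhibitor, a higher number a weaker inhibitor), compound 1 gives 1210 nM, and in this assay compound 2 gives 1960 nM. The change between them is pyrrolidin-1-yl in place of piperidin-1-yl on a saturated chain carbon, three bonds along the chain from an oxygen on an aromatic ring, and the step it made is a 1.6-fold higher number from compound 1 to compound 2 (0.21 log units; within the scatter). That step is small and sits inside the usual spread of repeat measurements, so the two amines read as equivalent on this core.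

Compound 3 `COc1cc2c(Oc3ccc(NC(=O)c4cc(-c5ccccc5)nc5ccc(F)cc45)cc3F)ccnc2cc1OCCCN1CCCCC1` carries a different core; the difference between the core of compound 3 and the core of compound 1 is not broken down here. In this assay compound 3 gives 120 nM, the lowest number among the three measured compounds, and its gaps to compound 1 and to compound 2 lie beyond the scatter.

Compound 4 `COc1cc2c(Oc3ccc(NC(=O)c4cc(-c5ccccc5)nc5ccc(F)cc45)cc3F)ccnc2cc1OCCCN1CCCC1` is not yet measured. It stands to compound 3 as compound 2 stands to compound 1: the change is pyrrolidin-1-yl in place of piperidin-1-yl on a saturated chain carbon, three bonds along the chain from an oxygen on an aromatic ring, the same change with the same place, now made on the core of compound 3. Because the earlier step of a 1.6-fold higher number from compound 1 to compound 2 (0.21 log units; within the scatter) was within the scatter, the expected step here is likewise small, a 1.6-fold higher number from compound 3 to compound 4 (0.20 log units; within the scatter), and it is an estimate that rests on a single prior pair. For compound 4 in this assay the expected value is 190 nM, with an expected range from 90 nM to 420 nM.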

Compound 4, half-maximal inhibitory concentration: 160 nM
Estimate against measurement, compound 4: 1.2-fold (0.07 log units) above; low and high end bracket the measured number.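

Carried to a second core, the exchange of piperidin-1-yl for pyrrolidin-1-yl gives a 1.3-fold higher number from compound 3 to compound 4 (0.12 log units; within the scatter) in this assay, and this step does not differ from the one seen on the first core: the same change on two cores in this assay, a 1.6-fold higher number (0.21 log units; within the scatter) from compound 1 to compound 2 and a 1.3-fold higher number (0.12 log units; within the scatter) from compound 3 to compound 4, 1.2-fold (0.08 log units) apart, within the scatter of two such steps

On these two cores, then, the change at this place, read in full as 3-(piperidin-1-yl)propyl to 3-(pyrrolidin-1-yl)propyl, carries over as a small step that stays within the scatter each time. This does not rank the two amines, since neither step stands clear of the scatter, and two pairs in one cell assay say nothing about a third core or about any other assay.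

The compounds shown leave open whether the same flat result would hold for other groups at the chain end, such as a morpholine, a piperazine or an open-chain dimethylamine, or for a shorter or longer chain in place of the propyl chain. Going by these compounds alone, they also leave open which part of the difference between the core of compound 1 and the core of compound 3 goes with the gap in their numbers, as no pair here separates those parts.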